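The source may hold more compounds than are shown below. What is called first, only, known or untested is meant among the compounds shown, and "the series" means these compounds.

Measured compounds:
- compound 1 `CCN(CC)C(=O)Nc1ncc(C(Oc2ccc3cc(Br)ccc3c2)c2ccc(Cl)cc2)s1`: "not toxic" (no number reported)
- compound 2 `COc1ccc(C(=O)Nc2ncc(C(Oc3ccc4cc(Br)ccc4c3)c3ccc(Cl)cc3)s2)cc1`: > 50000 nM
- compound 3 `O=C(Nc1ncc(C(Oc2ccc3cc(Br)ccc3c2)c2ccc(Cl)cc2)s1)c1ccc(F)cc1F`: "not toxic" (no number reported)

Three compounds share one core and differ only in the group carried on the nitrogen attached to the aromatic ring. In an ADME assay on HepG2 2.2.15 cells (Homo sapiens) for cytotoxicity (on this read-out higher numbers stand for lower toxicity in this test and lower numbers for higher toxicity in this test), compound 1 is reported as "not toxic" (no number reported) without a number. Compound 2 in this assay reaches only a limit of the test, > 50000 nM, which says the number was not found within the tested range. Compound 3 in this assay again is given as "not toxic" (no number reported) and no number. So compound 3 stands in a group where nothing was measured as a number: one entry is a limit, as described by the limit of > 50000 nM in this assay, at which 1 of the 3 values shown sits, and the other two carry a word instead of a value. Among the compounds with values here, no step between two measured compounds can be drawn from this.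

Compound 4 `O=S(=O)(Nc1ncc(C(Oc2ccc3cc(Br)ccc3c2)c2ccc(Cl)cc2)s1)c1cccs1` carries the change ((thiophen-2-yl)sulfonyl in place of (2,4-difluorophenyl)carbonyl on a nitrogen on an aromatic ring). Within the data shown here, with no measured step to lean on and all three neighbours showing no toxicity, no change beyond the scatter in this assay is expected in either direction. Compound 4 is therefore estimated to give 60000 nM in this assay, with a range from 20000 nM to 150000 nM, and most probably only a limit again.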

Compound 4, half-maximal cytotoxic concentration: "not toxic" (no number reported)
Compound 4: no number reported; the estimate stays without a comparison.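

In this assay, compound 3 and compound 4 each carry a word and no number, so no step can be read between them. The compounds shown leave open at what concentration any of them harms these cells, and whether changing the group on the nitrogen shifts that concentration at all.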